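A Benzylpyrrolidine Variant on a Sulfonamide Core

The source may hold more compounds than are shown below. What is called first, only, known or untested is meant among the compounds shown, and "the series" means these compounds.

Compound 1 `O=C(CN1CCCC1)N1CCC(NS(=O)(=O)c2cc(S(=O)(=O)c3ccccc3)ccc2C(F)(F)F)CC1`: 110 nM
Compound 2 `O=C(Cn1ccnc1)N1CCC(NS(=O)(=O)c2cc(S(=O)(=O)c3ccccc3)ccc2C(F)(F)F)CC1`: 30 nM
Compound 3 `O=C([C@@H]1CCCN1C(=O)N1CCOCC1)N1CCC(NS(=O)(=O)c2cc(S(=O)(=O)c3ccccc3)ccc2C(F)(F)F)CC1`: 40 nM

In an assay on isolated protein for binding affinity to secreted frizzled-related protein 1 (Homo sapiens), read by fluorescence (on this read-out lower numbers stand for stronger inhibition and higher numbers for weaker inhibition), compound 1 stands highest of the three numbers. Compound 2 lies below it: a 3.7-fold lower number from compound 1 to compound 2 (0.56 log units; beyond the scatter). Among the measured compounds shown here, compound 3, which also carries a pyrrolidin-2-yl on the carbonyl, sits at 40 nM; no single-change step links it to compound 1, so only the two values can be compared.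

Compound 4 `O=C([C@@H]1CCCN1Cc1ccccc1)N1CCC(NS(=O)(=O)c2cc(S(=O)(=O)c3ccccc3)ccc2C(F)(F)F)CC1` changes compound 1 in one place: 1-benzylpyrrolidin-2-yl in place of (pyrrolidin-1-yl)methyl on a carbonyl carbon. For the measured compounds named here, no measured step matches this change. Going by the values given here, the one measured step from compound 1, a 3.7-fold lower number from compound 1 to compound 2 (0.56 log units; beyond the scatter), altered the group on the same carbonyl and gave a modest gain, and compound 3 with its pyrrolidin-2-yl stands at 40 nM. A modest lowering, a 2.4-fold lower number from compound 1 to compound 4 (0.39 log units; beyond the scatter), is therefore expected for compound 4. The estimate for compound 4 is 45 nM, in the range 15 nM to 130 nM.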

Compound 4, half-maximal inhibitory concentration: 1400 nM
The estimate for compound 4 lay 31-fold (1.49 log units) below the measured number; the whole stated range lies below it.
By their numbers in this assay, from the lowest: compounds 2 and 3 (each within the scatter of the next); then compound 1; then compound 4.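

Not every change on this carbonyl carbon lowers the number: 1-benzylpyrrolidin-2-yl in place of (pyrrolidin-1-yl)methyl raises it (a 13-fold higher number from compound 1 to compound 4 (1.10 log units; beyond the scatter)), and the same group in place of (1H-imidazol-1-yl)methyl does so too (a 47-fold higher number from compound 2 to compound 4 (1.67 log units; beyond the scatter)). The group on the amine nitrogen in the ring also counts for much, since benzyl in place of (morpholin-4-yl)carbonyl gives a large rise (a 35-fold higher number from compound 3 to compound 4 (1.54 log units; beyond the scatter)). No measurement at hand explains these losses.

From the compounds shown here alone, whether a methyl group or a plain hydrogen on that ring nitrogen would stand nearer compound 3 or compound 4 stays open.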